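Thiocarbonyl end group: from dimethylamino to amino

This account rests on a few compounds, and the source may have more. Where it says the series, first, only, none or still open, it means among the compounds named here.

compound 1 `CN(C)C(=S)N/N=C/c1ccc2cccnc2n1` gives 630 nM
compound 2 `Cc1cccc(NC(=S)N/N=C/c2ccc3ccccc3n2)c1` gives > 100000 nM
compound 3 `N#Cc1ccc(NC(=S)N/N=C/c2ccc3ccccc3n2)cc1` gives 23700 nM

In a functional assay on SGC-7901 cells (Homo sapiens) for antiproliferative activity, read by sulforhodamine B assay, with a stated time of 72 h (a higher number here means a weaker inhibitor, a lower number a stronger inhibitor), compound 1 holds the lowest number (630 nM). Compound 3 gives 23700 nM, and the gap between these two compounds lies beyond the scatter. For compound 2 the value (> 100000 nM) is a limit of the assay and not a number.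

The next compound is compound 4 (`NC(=S)N/N=C/c1ccc2cccnc2n1`), which keeps the core of compound 1 and differs from it as follows: amino in place of dimethylamino on a thiocarbonyl carbon. The group that changes is therefore amino in place of dimethylamino on a thiocarbonyl carbon.

Going by the values given here, only one measured step bears on this, and only loosely, since it involves a different core and different groups: an at least 4.2-fold lower number from compound 2 to compound 3 (0.62 log units; beyond the scatter). It suggests that this assay responds to changes at this end of the series, beyond the scatter. Compound 1 already has the lowest number (630 nM), so a rise is expected rather than a fall.

The expected step, toward a higher number, is a 7.9-fold higher number from compound 1 to compound 4 (0.90 log units; beyond the scatter) and comparable in size or somewhat larger. For compound 4 the estimated value is 5000 nM, with an expected range from 1000 nM to 30000 nM and no narrower claim possible.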

Compound 4, half-maximal inhibitory concentration: > 100000 nM
Compound 4 was reported as a limit (the forecaster's own chance of this, stated with the estimate: 10%); middle value at least 20-fold (1.30 log units) from the limit.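

In this assay compound 4 gives > 100000 nM, which is a limit of the assay and not a number. The step, an at least 150-fold higher number from compound 1 to compound 4 (2.20 log units; beyond the scatter), is the only single change shown on the core of compound 1, and it shows that activity in this series depends heavily on the group held by the thiocarbonyl carbon: with amino in place of dimethylamino, no measurable number remains. The full size of the step stays unknown, since it is only a bound set by the assay: the limit of > 100000 nM in this assay, at which 2 of the 4 values shown sit.

The compounds shown leave open whether methylamino, diethylamino or a cyclic amine such as piperidine on that carbon would keep activity near that of compound 1 at 630 nM. Also open, on these data alone, is what a carbonyl in place of the thiocarbonyl would do.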